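Swapping sulfanyl for methyl, tested on a second ring

The source may report more compounds than this note shows. Statements on the series, on what has been measured and on what is new or still open speak of the compounds shown alone.

Compound 1 `Cc1nc(N)c2nc(O)n(Cc3ccccc3)c2n1` gives 1 uM in a functional assay (spleen, spleen) for activation, with Mus musculus as the target; a higher number here means that more compound is needed for the effect, a lower number that less compound is needed. Compound 2 `Nc1nc(S)nc2c1nc(O)n2Cc1ccccc1` gives 10 uM in this assay, and compound 3 `Nc1ncnc2c1nc(S)n2Cc1ccccc1` gives 10 uM in this assay, level with compound 2 at the digits shown. Compound 1 differs from compound 2 in one place: methyl in place of sulfanyl on an aromatic carbon. That change gave a 10-fold lower number from compound 2 to compound 1 (1.00 log units; beyond the scatter). Compound 4 `Cc1nc2c(N)ncnc2n1Cc1ccccc1` is not yet measured; it differs from compound 3 in one place: methyl in place of sulfanyl on an aromatic carbon. The difference between the cores of compound 2 and compound 3 is not broken down here. The two changes are the same kind of change, but the place differs: a six-membered aromatic ring with 2 nitrogen, meta to a fused ring, meta to an amino group and para to a fused ring, against a five-membered aromatic ring with 2 nitrogen, next to the ring atom that bears a group of 7 heavy atoms. The earlier step of a 10-fold lower number from compound 2 to compound 1 (1.00 log units; beyond the scatter) sat on a different ring, so a smaller gain is expected. The expected step is a 3.3-fold lower number from compound 3 to compound 4 (0.52 log units; beyond the scatter). Compound 4 is estimated at 3 uM, between 0.5 uM and 30 uM.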

Compound 4, minimum effective concentration: > 10 uM
Compound 4 gave a limit, no number; the forecaster's own chance of this, stated with the estimate: 5%; at least 3.3-fold (0.52 log units) between middle value and limit.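

In this assay compound 4 gives > 10 uM, which is a limit of the assay and not a number. Methyl in place of sulfanyl on the five-membered aromatic ring gave a number no lower from compound 3 to compound 4 (the limit leaves the size open), so the lower number seen with this change on the other core did not carry over: the same change on two cores in this assay, a 10-fold lower number (1.00 log units; beyond the scatter) from compound 2 to compound 1 and a number no lower (the limit leaves the size open) from compound 3 to compound 4, at least 10-fold (1.00 log units) apart, beyond the scatter of two such steps. This shows that the change cannot be assumed to act alike on both cores, but it does not show how far compound 4 lies from compound 3, nor whether the place of the change or the other differences between the cores decide the outcome.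

The compounds shown leave open what other groups would do at this place, such as an ethyl chain or a carboxylic acid.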